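Adding a chloro to compound 3 to give compound 4

This account rests on a few compounds, and the source may have more. Where it says the series, first, only, none or still open, it means among the compounds named here.

Measured so far in a functional assay on MDA-MB-231 cells (Homo sapiens) for cytotoxicity, read by MTT assay, with a stated time of 72 h; a lower number here means a stronger inhibitor, a higher number a weaker inhibitor
- compound 1 (`O=C(CN1CCN(c2nnc(Cc3ccccc3)c3ccccc23)CC1)Nc1ccc(F)c(C(F)(F)F)c1`) gives 760 nM
- compound 2 (`Cc1ccc(F)cc1NC(=O)CN1CCN(c2nnc(Cc3ccccc3)c3ccccc23)CC1`) gives 19200 nM
- compound 3 (`Cc1ccccc1NC(=O)CN1CCN(c2nnc(Cc3ccccc3)c3ccccc23)CC1`) gives 17300 nM

Compound 3 sits at the high end of these numbers, level with compound 2 and far from compound 1. Its gap to the nearest value is a 1.1-fold lower number from compound 2 to compound 3 (0.05 log units; within the scatter), while its gap to the furthest is a 23-fold higher number from compound 1 to compound 3 (1.36 log units; beyond the scatter). Compound 4 (`Cc1cccc(Cl)c1NC(=O)CN1CCN(c2nnc(Cc3ccccc3)c3ccccc23)CC1`) is compound 3 with chloro in place of hydrogen on an aromatic carbon, ortho to a large group and meta to a methyl group (chloro in place of hydrogen on an aromatic carbon). The 2-methylphenyl thus becomes 2-chloro-6-methylphenyl.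

The closest measured change is a 1.1-fold lower number from compound 2 to compound 3 (0.05 log units; within the scatter), which also swaps hydrogen and a halogen on an aromatic carbon, though the halogen there is fluoro. The larger steps, a 25-fold higher number from compound 1 to compound 2 (1.40 log units; beyond the scatter) and a 23-fold higher number from compound 1 to compound 3 (1.36 log units; beyond the scatter), replace the whole 4-fluoro-3-(trifluoromethyl)phenyl, which shows that this aromatic group can matter in this assay. Going by the values given here, no measured compound carries chloro, so the expected range stays wide. The expected change is small, estimated as a 1.2-fold lower number from compound 3 to compound 4 (0.06 log units; within the scatter), with no shift beyond the scatter anticipated. For compound 4 the estimated value is 15000 nM, with an expected range from 6000 nM to 35000 nM.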

Compound 4, half-maximal inhibitory concentration: 3920 nM
Beside the measured number, compound 4's estimate is 3.8-fold (0.58 log units) above it, outside the stated range (below it).
By their numbers in this assay, from the lowest: compound 1; then compound 4; then compounds 3 and 2 (each within the scatter of the next).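

Going by these compounds alone, the chloro in compound 4 shows that this place on the 2-methylphenyl ring responds to a single-atom change in this assay: the step is a 4.4-fold lower number from compound 3 to compound 4 (0.64 log units; beyond the scatter) and lies beyond the scatter, while the only earlier swap of hydrogen and a halogen, at another place on the ring and with fluoro, gave a 1.1-fold lower number from compound 2 to compound 3 (0.05 log units; within the scatter) and stayed within it. The 2-chloro-6-methylphenyl group also separates compound 4 from the fluoro-bearing ring of compound 2, with a 4.9-fold lower number from compound 2 to compound 4 (0.69 log units; beyond the scatter) beyond the scatter, but it does not reach the 4-fluoro-3-(trifluoromethyl)phenyl group, with a 5.2-fold higher number from compound 1 to compound 4 (0.71 log units; beyond the scatter) still beyond the scatter, so one chloro closes only part of the earlier gap. No supporting data are available to explain why this chloro lowers the number.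

The compounds shown leave open whether the step belongs to chloro itself or would also appear with bromo, methoxy or a nitrile at the same place. As far as these compounds go, it also remains open whether chloro would give the same step without the methyl group, or on the aromatic group of compound 1.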